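A few compounds are considered here, and "the series" means these few. Any claim that something is new, unique, unknown or untested is made for them only; others in the source may bear on it.

In a functional assay on SGC-7901 cells (Homo sapiens) for inhibition, read by MTT assay, with a stated time of 24 h (on this read-out lower numbers stand for stronger inhibition and higher numbers for weaker inhibition), compound 1 `CC1(C)[C@H]2CC[C@]1(C)N(Cc1cn(-c3ccccc3Cl)nn1)C(=O)C2` gives 220 nM and compound 2 `CC1(C)[C@H]2CC[C@]1(C)N(Cc1cn(-c3ccccc3O)nn1)C(=O)C2` gives 410 nM. Within the data shown here, these are the only two measured values, and they lie within the scatter of each other, so compound 2 cannot be separated from compound 1 on these numbers. The next entry is compound 3 `Cc1ccccc1-n1cc(CN2C(=O)C[C@@H]3CC[C@@]2(C)C3(C)C)nn1`, which has methyl in place of hydroxy on an aromatic carbon, ortho to a large group: methyl in place of hydroxy on an aromatic carbon. Among the measured compounds shown here, one measured step bears on this change: a 1.9-fold higher number from compound 1 to compound 2 (0.27 log units; within the scatter), where hydroxy took the place of chloro on an aromatic carbon. For the measured compounds named here, that step stayed within the scatter, and no measured compound carries methyl, so no step beyond the scatter is expected in this assay. The expected step is a 1.4-fold lower number from compound 2 to compound 3 (0.14 log units; within the scatter). Compound 3 is estimated at 300 nM, with an expected range of 120 nM to 700 nM.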

Compound 3, half-maximal inhibitory concentration: 350 nM
Compound 3: the middle estimate sits 1.2-fold (0.07 log units) below what was measured; the measured number falls inside the stated range.
By their numbers in this assay, from the lowest: compounds 1, 3 and 2 (each within the scatter of the next).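

On the aromatic carbon ortho to a large group, methyl now stands alongside chloro and hydroxy in this assay, with a 1.2-fold lower number from compound 2 to compound 3 (0.07 log units; within the scatter) and a 1.6-fold higher number from compound 1 to compound 3 (0.20 log units; within the scatter). Exchanging hydroxy for methyl removes the hydrogen-bond donor and acceptor counted for hydroxy, yet this pair stays within the scatter, so the three groups cannot be separated on these numbers. No measurement at hand explains this result.

Only chloro, hydroxy and methyl are shown at this place, so it remains open whether an amine, a carboxylic acid or a longer chain such as propyl would give a step beyond the scatter. Also open, going by these compounds, is whether the same reading holds with these groups on another carbon of the ring.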